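Lengthening the chain of compound 3

A few compounds are considered here, and "the series" means these few. Any claim that something is new, unique, unknown or untested is made for them only; others in the source may bear on it.

Measured in a functional assay on MCF7 cells (Homo sapiens) for inhibition, read by MTT assay, with stated times of 18 h and 4 h; a lower number here means a stronger inhibitor, a higher number a weaker inhibitor:
- compound 1 `CCCCCCCCCCOP(=O)(O)OCCSC(=S)N1CCCCCC1` gives 43300 nM
- compound 2 `CCCCCCCCCCCCCCCCOP(=O)(O)OCCSC(=S)N1CCN(C)CC1` gives > 100000 nM, which is a limit
- compound 3 `CCCCCCCCCCOP(=O)(O)OCCSC(=S)N1CCCCC1` gives 7240 nM

Compound 3 holds the lowest of the two actual numbers, and replacing azepan-1-yl with piperidin-1-yl gave a 6.0-fold lower number from compound 1 to compound 3 (0.78 log units; beyond the scatter). Compound 4 `CCCCCCCCCCCCCCCCOP(=O)(O)OCCSC(=S)N1CCCCC1` differs from compound 3 by hexyl in place of hydrogen on a saturated chain carbon, ten or more bonds along the chain from an oxygen on an unsaturated carbon. Going by the values given here, the one measured step changes the ring and not the chain, so it offers only a rough sense of scale. Compound 2 also carries the longer chain, though with a different ring, and it sits at the limit of > 100000 nM in this assay, at which 1 of the 3 values shown sits. A moderate weakening is therefore expected in this assay, with an estimated 2.8-fold higher number from compound 3 to compound 4 (0.44 log units; beyond the scatter). For compound 4 the estimated value is 20000 nM, with an expected range of 4000 nM to 100000 nM.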

Compound 4, half-maximal inhibitory concentration: 29000 nM
The estimate for compound 4 lay 1.5-fold (0.16 log units) below the measured number, within the range that was stated.
By their numbers in this assay, from the lowest: compound 3; then compounds 4 and 1 (each within the scatter of the next). At a limit, above all of these: compound 2.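

In this assay the chain now has a step of its own, a 4.0-fold higher number from compound 3 to compound 4 (0.60 log units; beyond the scatter) for hexyl in place of hydrogen, with the ring held fixed. The ring still matters on the longer chain, with an at least 3.4-fold lower number from compound 2 to compound 4 (0.53 log units; beyond the scatter) when piperidin-1-yl replaces 4-methylpiperazin-1-yl. That second step rests on a limit for compound 2, not a number: the limit of > 100000 nM in this assay, at which 1 of the 4 values shown sits.

On these data alone, whether a longer chain would move the number further remains open. So does the effect of a carboxylic acid at the chain end.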